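Nitro for fluoro on the benzyl ring of a ketone

The source may report more compounds than this note shows. Statements on the series, on what has been measured and on what is new or still open speak of the compounds shown alone.

Of the compounds shown here, two have so far been measured in an assay on isolated protein for inhibition of Amine oxidase [flavin-containing] B (Homo sapiens), read by Amplex Red, with a stated time of 15 min; on this read-out higher numbers stand for weaker inhibition and lower numbers for stronger inhibition. Compound 1, `CC(=O)c1ccc(OCc2ccc(C(F)(F)F)cc2)cc1`, gives 77.8 nM in this assay. Compound 2, `CC(=O)c1cccc(OCc2ccc(F)cc2)c1`, gives 86.4 nM in this assay. Compound 2 thus stands at the higher of the two numbers, yet its nearest neighbour, compound 1, lies within the scatter, so the two read alike and no order between them can be drawn.

The next compound, compound 3, `CC(=O)c1cccc(OCc2ccc([N+](=O)[O-])cc2)c1`, has not yet been measured in this assay. It differs from compound 2 in a single place: nitro in place of fluoro on an aromatic carbon, on an aromatic carbon of a six-membered aromatic ring of carbon only, para to a large group. Among the compounds with values here, no measured pair shows this change, so its direction and size rest on expectation alone. Because compound 2 gives 86.4 nM and the change is confined to one substituent, compound 3 is expected to land close by, with an expected step of a 1.3-fold lower number from compound 2 to compound 3 (0.12 log units; within the scatter) that may not exceed the scatter. Compound 3 is therefore estimated at 65 nM, within a range from 20 nM to 210 nM.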

Compound 3, half-maximal inhibitory concentration: 75.4 nM
For compound 3 the middle estimate is 1.2-fold (0.06 log units) below the measured one; the range from low to high includes it.
By their numbers in this assay, from the lowest: compounds 3, 1 and 2 (each within the scatter of the next).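

Nitro in place of fluoro on an aromatic carbon, para to a large group, gives the first step measured at this position in this assay, with a 1.1-fold lower number from compound 2 to compound 3 (0.06 log units; within the scatter) as its size. Within the data shown here, the earlier compounds offered no pair differing in one place, so this is the first direct reading of a change at this carbon. Here, three heavy atoms with two hydrogen-bond acceptors take the place of a single fluorine with none, and the read-out in this assay does not move beyond the scatter. No measurement on these compounds offers an explanation for this result.

Among these compounds, whether an amine, a carboxylic acid or a longer chain on this same carbon would also read alike with compound 2 remains open, since nitro and fluoro are the only two groups compared here. Also open, from the compounds shown here alone, is whether the same exchange would read alike on the core of compound 1, as this single pair speaks only for the core it shares.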